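The compounds below may be only part of what the source reports. "The series", "measured", "known", "first", "only" and "open" are said of these compounds alone.

Measured compounds:
Compound 1, `CNc1nc(SC)nc2ncccc12`, gives 2920 nM in a functional assay (Nicotiana tabacum); a lower number here means a stronger inhibitor, a higher number a weaker inhibitor.
Compound 2, `CSc1nc(NC2CC2)c2cccnc2n1`, gives 4900 nM.
Compound 3, `CCC(C)Nc1nc(SC)nc2ncccc12`, gives 860 nM.

Compound 2 has the highest of the three numbers; the step up to it is a 1.7-fold higher number from compound 1 to compound 2 (0.22 log units; within the scatter), while the step down from it is a 5.7-fold lower number from compound 2 to compound 3 (0.76 log units; beyond the scatter). Compound 4, `CCOCCNc1nc(SC)nc2ncccc12`, has not been measured. It differs from compound 2 in one place: 2-ethoxyethyl in place of cyclopropyl on a nitrogen on an aromatic ring. The bearing steps are those from the cyclopropyl and methyl groups to a larger open chain, a 5.7-fold lower number from compound 2 to compound 3 (0.76 log units; beyond the scatter) and a 3.4-fold lower number from compound 1 to compound 3 (0.53 log units; beyond the scatter). An open chain of five heavy atoms is therefore expected to give a modest lowering, a 3.1-fold lower number from compound 2 to compound 4 (0.49 log units; beyond the scatter), so compound 4 is estimated at 1600 nM, between 600 nM and 4500 nM.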

Compound 4, half-maximal inhibitory concentration: 7590 nM
Beside the measured number, compound 4's estimate is 4.7-fold (0.68 log units) below it; the measured number lies above the stated range.
By their numbers in this assay, from the lowest: compound 3; then compounds 1, 2 and 4 (each within the scatter of the next, the first and the last beyond it).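

In this assay, a larger group on this nitrogen does not by itself lower the number: 2-ethoxyethyl matches cyclopropyl (a 1.5-fold higher number from compound 2 to compound 4 (0.19 log units; within the scatter)) and falls short of sec-butyl (an 8.8-fold higher number from compound 3 to compound 4 (0.95 log units; beyond the scatter)). It also does worse than the small methyl group (a 2.6-fold higher number from compound 1 to compound 4 (0.41 log units; beyond the scatter)), so among these compounds only sec-butyl brings a gain. Nothing measured here explains the gap between the two open chains. On these data alone, whether a plain pentyl chain, with carbon in place of the oxygen, would follow compound 3 or compound 4 remains open.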